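Para substituent swap on the sulfonyl ring of compound 3

A few compounds are considered here, and "the series" means these few. Any claim that something is new, unique, unknown or untested is made for them only; others in the source may bear on it.

Compound 3 `CN(c1ccc2[nH]c(-c3n[nH]c4ccccc34)cc2n1)S(=O)(=O)c1ccc(Br)cc1` holds the highest of the three numbers in a functional assay on HL-60 cells (Homo sapiens) for antiproliferative activity, read by MTT assay, with a stated time of 72 h (on this read-out higher numbers stand for weaker inhibition and lower numbers for stronger inhibition), giving 6240 nM. Compound 1 `CCC(=O)N(C)c1ccc2[nH]c(-c3n[nH]c4ccccc34)cc2n1` gives 6130 nM in this assay, and a 1.0-fold higher number from compound 1 to compound 3 (0.01 log units; within the scatter). Compound 2 `CN(c1ccc2[nH]c(-c3n[nH]c4ccccc34)cc2n1)S(=O)(=O)c1ccc(Cl)cc1` gives 770 nM, and an 8.1-fold higher number from compound 2 to compound 3 (0.91 log units; beyond the scatter). Compound 4 `CN(c1ccc2[nH]c(-c3n[nH]c4ccccc34)cc2n1)S(=O)(=O)c1ccc(OC(F)(F)F)cc1` differs from compound 3 by trifluoromethoxy in place of bromo on an aromatic carbon. Going by the values given here, the only step that bears on this change is the halogen swap at the same aromatic carbon, an 8.1-fold higher number from compound 2 to compound 3 (0.91 log units; beyond the scatter), which shows that a change there can move the number beyond the scatter; no measured step involves trifluoromethoxy. A modest lowering is therefore expected, a 2.1-fold lower number from compound 3 to compound 4 (0.32 log units; beyond the scatter), though with wide uncertainty. Compound 4 is estimated at 3000 nM, with a range from 600 nM to 15000 nM.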

Compound 4, half-maximal inhibitory concentration: 1170 nM
Compound 4: middle estimate off by 2.6-fold (0.41 log units), on the high side; the measured number falls inside the stated range.
By their numbers in this assay, from the lowest: compounds 2 and 4 (each within the scatter of the next); then compounds 1 and 3 (each within the scatter of the next).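

In this assay the high number of compound 3 proves not to be shared by every larger group on this aromatic carbon, with a 5.3-fold lower number from compound 3 to compound 4 (0.73 log units; beyond the scatter). Trifluoromethoxy and chloro cannot be told apart here, given a 1.5-fold higher number from compound 2 to compound 4 (0.18 log units; within the scatter), so among the three groups at this place bromo alone stands apart. No measured evidence accounts for this. As far as these compounds go, whether fluoro, methoxy or nitrile at this place would fall with chloro and trifluoromethoxy or with bromo stays open. So does whether an amine would keep the number low.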